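The source may report more compounds than this note shows. Statements on the series, on what has been measured and on what is new or still open speak of the compounds shown alone.

Among the measured compounds shown here, compound 2 `C=C1CN(S(=O)(=O)c2ccc(C)cc2)CCc2cc(OC)cc(n2)CCN(S(=O)(=O)c2ccc(C)cc2)C1` is one of two compounds measured in a physicochemical assay for solubility, read by spectrophotometry, using the shake flask method, in phosphate buffer, measured as thermodynamic solubility, with a stated time of 72 h, at pH 7.4; a higher number here means a more soluble compound, a lower number a less soluble compound; compound 2 gives 28000 nM. The other, compound 1 `C=C1CN(S(=O)(=O)c2ccc(C)cc2)CCc2cc(CC(C)C)cc(n2)CCN(S(=O)(=O)c2ccc(C)cc2)C1`, gives 29000 nM, and the step of a 1.0-fold lower number from compound 1 to compound 2 (0.02 log units; within the scatter) shows that swapping isobutyl for methoxy left the number where it was. Compound 3 `C=C1CN(S(=O)(=O)c2ccc(C)cc2)CCc2cc(C(C)(C)C)cc(n2)CCN(S(=O)(=O)c2ccc(C)cc2)C1` carries the change tert-butyl in place of methoxy on an aromatic carbon at the same place. For the measured compounds named here, the only step that bears on it is a 1.0-fold lower number from compound 1 to compound 2 (0.02 log units; within the scatter), which was flat, so for compound 3 a step of a 1.1-fold lower number from compound 2 to compound 3 (0.05 log units; within the scatter) is expected, within the scatter. Compound 3 is therefore estimated at 25000 nM, with a range of 12000 nM to 55000 nM.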

Compound 3, solubility: 20000 nM
Estimate against measurement, compound 3: 1.3-fold (0.10 log units) above; measured number inside the range.
By their numbers in this assay, from the lowest: compounds 3, 2 and 1 (each within the scatter of the next).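

At this place, opposite the ring nitrogen, tert-butyl extends the flat picture in this assay, with a 1.4-fold lower number from compound 2 to compound 3 (0.15 log units; within the scatter) and a 1.5-fold lower number from compound 1 to compound 3 (0.16 log units; within the scatter). Methoxy, which carries a hydrogen-bond acceptor, and tert-butyl, which carries none, therefore cannot be told apart here, and neither can isobutyl and tert-butyl. No measured evidence is available to explain this.

The compounds shown leave open whether an amine or a carboxylic acid at this place would shift the number beyond the scatter. They also leave open whether other positions on the shared core behave the same way.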